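The compounds below may be only part of what the source reports. "The series", "measured", "known", "first", "only" and "open" are said of these compounds alone.

In an ADME assay on NHDF cells (Homo sapiens) for cytotoxicity, read by MTT assay, with a stated time of 72 h (on this read-out lower numbers stand for stronger inhibition and higher numbers for weaker inhibition), two compounds that share a core have been measured so far. Compound 1 `COc1cccc(/C=C2\CCC/C(=C\c3cccc(OC)c3OC)C2=O)c1` gives 16400 nM, and compound 2 `COc1cccc(/C=C2\CCC/C(=C\c3cccc(O)c3)C2=O)c1OC` gives 19300 nM. These two numbers lie within the usual scatter of each other, so compound 2 cannot be ranked against compound 1. Compound 3 `COc1cccc(/C=C2\CCC/C(=C\c3ccc(O)cc3)C2=O)c1OC` has the same atoms as compound 2, joined differently: 4-hydroxyphenyl in place of 3-hydroxyphenyl on a double-bonded chain carbon bound to a double-bonded ring carbon. Going by the values given here, the only measured step available is a 1.2-fold higher number from compound 1 to compound 2 (0.07 log units; within the scatter), where hydrogen takes the place of methyl on an oxygen on an aromatic ring. Among the compounds with values here, that is a different change and a small step, and no measured pair swaps 3-hydroxyphenyl for 4-hydroxyphenyl. No shift beyond the scatter is therefore expected in this assay, and the estimated step is a 1.1-fold lower number from compound 2 to compound 3 (0.03 log units; within the scatter). Compound 3 is expected to give about 18000 nM, with an estimated range of 9000 nM to 38000 nM.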

Compound 3, half-maximal inhibitory concentration: > 50000 nM
Compound 3 was reported as a limit; the forecaster's own chance of this, stated with the estimate: 8%; middle value at least 2.7-fold (0.44 log units) from the limit.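

In this assay the result for compound 3 is a limit of the assay and not a number: the limit of > 50000 nM in this assay, at which 1 of the 3 values shown sits.

Going by these compounds alone, earlier, the only step at this place, hydrogen in place of methyl on an oxygen, stayed within the scatter: a 1.2-fold higher number from compound 1 to compound 2 (0.07 log units; within the scatter). Now 4-hydroxyphenyl in place of 3-hydroxyphenyl, with the same atoms joined differently, gives an at least 2.5-fold higher number from compound 2 to compound 3 (0.41 log units; beyond the scatter), and 4-hydroxyphenyl in place of 3-methoxyphenyl gives an at least 3.0-fold higher number from compound 1 to compound 3 (0.48 log units; beyond the scatter), so in these compounds where the hydroxyl sits on the phenyl ring matters more than whether the oxygen carries a methyl.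

Going by these compounds, how far compound 3 lies past its limit stays open, and with it the full size of both steps. Also open, on these data alone, is whether an amine or a carboxylic acid in place of the hydroxyl on this phenyl ring would shift the number in the same way.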